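The source may hold more compounds than are shown below. What is called first, only, known or untested is meant among the compounds shown, and "the series" means these compounds.

Measured so far in a physicochemical assay for solubility, read by spectrophotometry, in phosphate buffer, with a stated time of 2 h, at pH 7.4; on this read-out lower numbers stand for lower solubility and higher numbers for higher solubility:
- Compound 1, `COc1ccc2[nH]c(C(=O)N3CC(=O)N(Cc4ccccc4)[C@@H](CN4CCCCC4)C3)cc2c1`, gives > 25000 nM, which is a limit of the assay rather than a number.
- Compound 2, `COc1ccc2[nH]c(C(=O)N3CC(=O)N(Cc4ccccc4)[C@@H](CN4CCN(c5ccccn5)CC4)C3)cc2c1`, gives 30200 nM.

Compound 1 thus stands only at a limit in this assay, as noted by the limit of > 25000 nM in this assay, at which 1 of the 2 values shown sits. Among the measured compounds shown here, the one measured step, a step that the limit leaves unreadable from compound 1 to compound 2, is therefore of unreadable size, and it concerns the saturated amine, not the benzyl group. The compound to be measured is compound 3, `COc1ccc2[nH]c(C(=O)N3CC(=O)N(Cc4cccc(OC(F)F)c4)[C@@H](CN4CCCCC4)C3)cc2c1`, which differs from compound 1 by difluoromethoxy in place of hydrogen on an aromatic carbon. For the measured compounds named here, no measured step touches this position, so nothing here speaks for a change beyond the scatter in this assay. Compound 3 is therefore expected to sit about where compound 1 does, with a step of a number no higher from compound 1 to compound 3 (the limit leaves the size open). The estimate for compound 3 in this assay is 25000 nM, within a range from 8000 nM to 60000 nM, and a further limit-only reading remains plausible.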

Compound 3, solubility: 26400 nM
Beside the measured number, compound 3's estimate is 1.1-fold (0.02 log units) below it; the range from low to high includes it.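

The size of the step between compound 1 and compound 3 in this assay cannot be read, because compound 1 has only a limit and not a number: the limit of > 25000 nM in this assay, at which 1 of the 3 values shown sits. The compounds shown leave open how far difluoromethoxy in place of hydrogen on an aromatic carbon moves this reading, and in which direction.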